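Shortening the side chain at the thiourea stereocentre

The compounds below may be only part of what the source reports. "The series", "measured", "known", "first", "only" and "open" are said of these compounds alone.

Compound 1 `CC(C)[C@H](NC(=S)NCc1ccccc1)c1nc2ccccc2[nH]1` gives 56100 nM in a functional assay on A549 cells (Homo sapiens) for cytotoxicity, read by MTT assay; a lower number here means a stronger inhibitor, a higher number a weaker inhibitor.
Compound 2 `CC(C)[C@@H](NC(=S)NCc1ccccc1)c1nc2ccccc2[nH]1` gives 11300 nM in this assay.
Compound 3 `CC(C)[C@@H](NC(=S)Nc1ccccc1)c1nc2ccccc2[nH]1` gives 31500 nM in this assay.

Compound 2 has the lowest number of the three, so in this assay it is the strongest inhibitor: compound 3 sits nearest, and compound 1 furthest. Two measured steps lead to it. Inverting the drawn configuration at the saturated chain carbon gives a 5.0-fold lower number from compound 1 to compound 2 (0.70 log units; beyond the scatter); this is tied to the fact that compounds 1 and 2 differ only in the configuration as drawn. Swapping the benzyl for a phenyl on the thiourea nitrogen gives a 2.8-fold higher number from compound 2 to compound 3 (0.45 log units; beyond the scatter).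

Compound 4 `C[C@@H](NC(=S)NCc1ccccc1)c1nc2ccccc2[nH]1` keeps the configuration and the benzyl thiourea of compound 2 and changes only the branch at the stereocentre: methyl in place of isopropyl on a saturated chain carbon bound to an amide-type nitrogen and an aromatic carbon. Among the compounds with values here, neither measured step alters this group, so no step reports directly on its size. The only hint is that the arrangement at this same carbon, in the step from compound 1 to compound 2, moved the number beyond the scatter, which shows that this carbon is not indifferent, without saying in which direction a smaller group would push. For compound 4 the step of a 1.3-fold higher number from compound 2 to compound 4 (0.12 log units; within the scatter) is therefore expected to stay within the scatter, with a wide range on either side.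

Compound 4 is thus estimated to give 15000 nM, between 5000 nM and 45000 nM.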

Compound 4, half-maximal inhibitory concentration: 18700 nM
For compound 4 the middle estimate is 1.2-fold (0.10 log units) below the measured one; low and high end bracket the measured number.
By their numbers in this assay, from the lowest: compounds 2, 4, 3 and 1 (each within the scatter of the next, the first and the last beyond it).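

The change from isopropyl to methyl on this saturated chain carbon gives a 1.7-fold higher number from compound 2 to compound 4 (0.22 log units; within the scatter) in this assay. Within the data shown here, this is the first direct reading on the group at this carbon: with the drawn configuration and the benzyl thiourea held fixed, the count of carbons in the branch falls from 3 to 1 without the number leaving the scatter, whereas the step that inverted this same carbon lay beyond it. No available evidence explains why this change leaves the number within the scatter.

It remains open whether the drawn configuration still matters when methyl occupies this carbon, since only one arrangement of the methyl compound is shown. The compounds shown also leave open how a longer chain, such as n-butyl, or a carboxylic acid on this carbon would read.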